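The source may hold more compounds than are shown below. What is called first, only, known or untested is meant among the compounds shown, and "the series" means these compounds.

Measured so far in a functional assay on M21 cells (Homo sapiens) for antiproliferative activity, read by sulforhodamine B assay, with a stated time of 48 h; on this read-out lower numbers stand for stronger inhibition and higher numbers for weaker inhibition:
compound 1 `CC(=O)Nc1cccc(S(=O)(=O)Oc2ccccc2C(C)C)c1`: 31000 nM
compound 2 `CC(C)C(=O)Nc1ccc(S(=O)(=O)Oc2ccccc2C(C)C)cc1`: 11000 nM
compound 3 `CC(C)C(=O)Nc1ccc(S(=O)(=O)Oc2ccccc2I)cc1`: 13000 nM

Compound 2 gives the lowest of the three numbers in this assay, though compound 3 stands within the scatter of it, with a 1.2-fold higher number from compound 2 to compound 3 (0.07 log units; within the scatter), a change made on an aromatic carbon. Within the data shown here, compound 1 stands furthest from compound 2; the two values differ beyond the scatter, but the two structures differ in more than one place, so this pair yields no single step.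

Compound 4 `CCNC(=O)Nc1ccc(S(=O)(=O)Oc2ccccc2C(C)C)cc1` is not yet measured. It differs from compound 2 by ethylamino in place of isopropyl on a carbonyl carbon; cut one bond further out, the change reads isopropylcarbonyl to ethylcarbamoyl, or (isopropylcarbonyl)amino to (ethylcarbamoyl)amino. Among the measured compounds shown here, none of the measured steps touches the carbonyl carbon: the only single-place step, from compound 2 to compound 3, concerns a different site and was within the scatter, and the gap between compound 1 and compound 2 cannot be assigned to the acyl group alone. There is thus no measured basis for a step in either direction, and the expectation for compound 4 is no step beyond the scatter, namely a 1.1-fold higher number from compound 2 to compound 4 (0.04 log units; within the scatter). Compound 4 is accordingly estimated at 12000 nM, with a range from 4000 nM to 40000 nM.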

Compound 4, half-maximal inhibitory concentration: 4700 nM
For compound 4 the middle estimate is 2.6-fold (0.41 log units) above the measured one, and the stated range covers the measured number.
By their numbers in this assay, from the lowest: compound 4; then compounds 2 and 3 (each within the scatter of the next); then compound 1.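

In this assay, the carbonyl carbon is the only site among the single-place steps shown where a change moves the number beyond the scatter: ethylamino in place of isopropyl gives a 2.3-fold lower number from compound 2 to compound 4 (0.37 log units; beyond the scatter), a modest step, whereas the aromatic-carbon change in a 1.2-fold higher number from compound 2 to compound 3 (0.07 log units; within the scatter) stays within it. The groups that leave and enter both hold 3 heavy atoms, so this step comes without a change in that count, but ethylamino brings a nitrogen and a hydrogen-bond donor that isopropyl lacks, turning (isopropylcarbonyl)amino into (ethylcarbamoyl)amino. No measurement available here accounts for the step or separates the contribution of the nitrogen from that of the rest of the group.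

The compounds shown leave open whether dimethylamino, which has no amide hydrogen, would keep the lower number, and whether a longer chain such as propylamino or butylamino would lower it further. From the compounds shown here alone, it also remains open whether ethylamino at this carbonyl carbon gives a comparable step on the core of compound 3, which carries iodo in place of isopropyl.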